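The source may hold more compounds than are shown below. What is called first, only, known or untested is meant among the compounds shown, and "the series" means these compounds.

Of the compounds shown here, two from this series have been measured in a functional assay on a cell-free system (plasma) for inhibition of thromboxane A2 receptor (Homo sapiens), read by turbidimetry; a higher number here means a weaker inhibitor, a lower number a stronger inhibitor. Compound 1, `O=C(O)CCC/C=C\CC1=CCC[C@@H]1NS(=O)(=O)c1ccccc1`, carries a plain phenyl sulfonamide on its core and a chain ending in a carboxylic acid; in this assay compound 1 gives 2300 nM. Compound 2, `Cc1ccc(S(=O)(=O)N[C@H]2CCC=C2CCCCOCC(=O)O)cc1`, keeps the same core and sulfonamide arrangement but bears a 4-methylphenyl group on the sulfonyl sulfur and an ether-linked acid chain; in this assay compound 2 gives 1900 nM. Of the two numbers, that of compound 2 is the lower, yet the gap to compound 1 lies within the ordinary scatter of repeated measurements, so the two are best read as indistinguishable.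

Compound 3, `O=C(O)COCCCCC1=CCC[C@@H]1NS(=O)(=O)c1ccc(F)cc1F`, is not yet measured. It differs from compound 2 in one place: 2,4-difluorophenyl in place of 4-methylphenyl on a sulfonyl sulfur. Within the data shown here, no measured pair in this set shows what such a change does, so the expectation can only lean on how little the two measured compounds differ from each other. The step from compound 2 to compound 3 is expected to be small, a 1.2-fold lower number from compound 2 to compound 3 (0.07 log units; within the scatter), with no clear direction. Compound 3 is therefore expected to give about 1600 nM, most likely between 500 nM and 5000 nM.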

Compound 3, half-maximal inhibitory concentration: 1800 nM
Compound 3: the middle estimate sits 1.1-fold (0.05 log units) below what was measured, within the range that was stated.
By their numbers in this assay, from the lowest: compounds 3, 2 and 1 (each within the scatter of the next).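

In this assay, among these compounds, the replacement of 4-methylphenyl by 2,4-difluorophenyl on a sulfonyl sulfur gives a 1.1-fold lower number from compound 2 to compound 3 (0.02 log units; within the scatter) and so provides the first pair in this set that differs in only one place. On this chain and core, the two compounds cannot be told apart, even though one ring carries a methyl group and the other two fluorine atoms. The data on hand offer no measurement that would account for this likeness between the two rings.

Going by these compounds, the result covers only these two aromatic groups, so it remains open whether the sulfonyl sulfur would tolerate something more different, such as a pyridine ring, a naphthyl group or a plain butyl chain. It also leaves open whether the same swap would read alike on another chain, and whether a tetrazole in place of the carboxylic acid would alter the picture at all.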